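The source may hold more compounds than are shown below. What is called first, only, known or untested is meant among the compounds shown, and "the series" means these compounds.

Measured in a functional assay (trachea) with Cavia porcellus as the target; a higher number here means a weaker inhibitor, a lower number a stronger inhibitor:
- Compound 1 `CCn1nc(-c2cccnc2)c2ccccc2c1=O`: 1320 nM.
- Compound 2 `CCOC(=O)Cn1nc(-c2cccnc2)c2ccccc2c1=O`: 43700 nM.
- Compound 3 `O=C(O)CCCn1nc(-c2cccnc2)c2ccccc2c1=O`: > 100000 nM, a limit and not a number.

Compound 3 stands at the weak end of the series, and (the limit of > 100000 nM in this assay, at which 1 of the 3 values shown sits). Its true position is therefore open on one side.

Next is compound 4 `O=C(O)c1ccc(Cn2nc(-c3cccnc3)c3ccccc3c2=O)cc1`, in which 4-carboxyphenyl comes in place of 2-carboxyethyl on a saturated chain carbon bound to an aromatic nitrogen: 4-carboxyphenyl in place of 2-carboxyethyl on a saturated chain carbon bound to an aromatic nitrogen. The entering group keeps a carboxy group, but it also brings a six-membered aromatic ring of carbon only.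

Closest to this change is an at least 75-fold higher number from compound 1 to compound 3 (1.87 log units; beyond the scatter), a large step that introduced a chain ending in a carboxy group. Also relevant are a 33-fold higher number from compound 1 to compound 2 (1.52 log units; beyond the scatter), likewise large, and an at least 2.2-fold higher number from compound 2 to compound 3 (0.35 log units; beyond the scatter), which is at least modest. For the measured compounds named here, no measured step replaces a chain with an aromatic ring, so the data only loosely constrain this one.

With an at least 75-fold higher number from compound 1 to compound 3 (1.87 log units; beyond the scatter) as the guide, no step beyond the scatter is expected in this assay, and a return towards compound 1 at 1320 nM is not expected. The expected outcome is a number no higher from compound 3 to compound 4 (the limit leaves the size open). For compound 4 the estimate is 100000 nM, with an expected range of 20000 nM to 300000 nM.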

Compound 4, half-maximal inhibitory concentration: 17000 nM
Compound 4: the middle estimate sits 5.9-fold (0.77 log units) above what was measured, and the stated range ends above it.
By their numbers in this assay, from the lowest: compound 1; then compound 4; then compound 2. At a limit, above all of these: compound 3.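

On the saturated chain carbon bound to an aromatic nitrogen, the presence of a carboxy group does not settle the outcome in this assay: 4-carboxyphenyl in place of 2-carboxyethyl gives an at least 5.8-fold lower number from compound 3 to compound 4 (0.76 log units; beyond the scatter). The value of compound 3 is a limit of the assay and not a number, so the full size of that step stays unknown: the limit of > 100000 nM in this assay, at which 1 of the 4 values shown sits.

In this assay, for the compounds shown here, 4-carboxyphenyl also compares favourably with ethoxycarbonyl, giving a 2.6-fold lower number from compound 2 to compound 4 (0.41 log units; beyond the scatter), but it does not match the methyl group that completes the ethyl chain of the first compound, giving a 13-fold higher number from compound 1 to compound 4 (1.11 log units; beyond the scatter).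

The compounds shown do not separate the part played by the aromatic ring from that played by the carboxy group attached to it. How phenyl with no carboxy group, or an aminophenyl group, would stand on the same saturated chain carbon remains an open question for the series.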